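Moving the Methyl Along the Sulfonyl Phenyl Ring

The source may report more compounds than this note shows. Statements on the series, on what has been measured and on what is new or still open speak of the compounds shown alone.

Within the data shown here, compound 2 `Cc1ccccc1S(=O)(=O)Nc1ccc(-c2nc3ccccc3o2)cc1` is one of two compounds measured in an assay on cells for inhibition of HSP60/HSP10 (Homo sapiens), with a stated time of 60 min; on this read-out higher numbers stand for weaker inhibition and lower numbers for stronger inhibition. In this assay, among the measured compounds shown here, compound 2 gives 85000 nM, the only numerical value shown so far. Compound 1 `CCc1ccc(S(=O)(=O)Nc2ccc(-c3nc4ccccc4o3)cc2)cc1` gives > 100000 nM, which is a limit of the assay rather than a number. For the measured compounds named here, the one measured step, an at least 1.1-fold lower number from compound 1 to compound 2 (0.07 log units; that floor lies within the scatter), is bounded only because of the limit (the limit of > 100000 nM in this assay, at which 1 of the 2 values shown sits). Compound 3 `Cc1cccc(S(=O)(=O)Nc2ccc(-c3nc4ccccc4o3)cc2)c1` has not yet been measured. It differs from compound 2 in one place: 3-methylphenyl in place of 2-methylphenyl on a sulfonyl sulfur. Going by the values given here, no measured step exchanges a 2-methylphenyl for a 3-methylphenyl, so the only guide is that compound 1 and compound 2 both sit near the weak end of this assay and within the scatter of each other. The expected step is a 1.1-fold higher number from compound 2 to compound 3 (0.02 log units; within the scatter), a change no larger than the usual scatter. Compound 3 is therefore estimated at 90000 nM, with a range from 30000 nM to 300000 nM, and with a fair chance that the assay again reports only a limit.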

Compound 3, half-maximal inhibitory concentration: > 100000 nM
Compound 3 was reported as a limit (the forecaster's own chance of this, stated with the estimate: 45%); at least 1.1-fold (0.04 log units) between middle value and limit.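

Among these compounds, this is the first measured step that keeps the methyl group and changes only where it sits on the ring: in this assay, exchanging 2-methylphenyl for 3-methylphenyl on the sulfonyl sulfur gives an at least 1.1-fold higher number from compound 2 to compound 3 (0.07 log units; that floor lies within the scatter). Compound 3 is reported only as a limit, so this figure is a floor and not a measured size, and it does not show that moving the methyl makes a real difference. The step from compound 1 to compound 3 cannot be read because both compounds stand at the same limit: the limit of > 100000 nM in this assay, at which 2 of the 3 values shown sit.

Compound 2, at 85000 nM, still gives the only numerical value, and the compounds shown leave open whether a phenyl ring carrying an amine or a carboxylic acid on the sulfonyl sulfur would give a clearly lower number. They also leave open what a plain phenyl with no alkyl group would give, and so whether the methyl and ethyl groups matter at all on this read-out.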